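A few compounds are considered here, and "the series" means these few. Any claim that something is new, unique, unknown or untested is made for them only; others in the source may bear on it.

Compound 1 `CC#C[C@@H](CC(=O)O)c1ccc(OC[C@H]2COc3ccccc3O2)cc1`: 90 nM
Compound 2 `CC#C[C@@H](CC(=O)O)c1ccc(OC[C@H]2COc3ccc(OC(C)C)cc3O2)cc1`: 280 nM

In a functional assay on HEK293 cells for agonist activity at Free fatty acid receptor 1 (Homo sapiens), read by fluorescence and calcium flux, with a stated time of 10 min (on this read-out lower numbers stand for an effect already at smaller amounts and higher numbers for an effect only at larger amounts of compound), compound 2 gives the highest of these two numbers; its nearest neighbour is compound 1, separated by a 3.1-fold higher number from compound 1 to compound 2 (0.49 log units; beyond the scatter). Compound 3 `CC#C[C@@H](CC(=O)O)c1ccc(OC[C@H]2COc3ccc(C#N)cc3O2)cc1` differs from compound 2 by cyano in place of isopropoxy on an aromatic carbon. Going by the values given here, the only measured step bearing on this position is a 3.1-fold higher number from compound 1 to compound 2 (0.49 log units; beyond the scatter), in which isopropoxy took the place of hydrogen; a cyano group at this position has no measurement yet. Compound 3 is therefore expected to fall between the two measured values, a step of a 1.9-fold lower number from compound 2 to compound 3 (0.27 log units; within the scatter). The estimate for compound 3 is 150 nM, ranging from 60 nM to 400 nM.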

Compound 3, half-maximal effective concentration: 2100 nM
Compound 3: middle estimate off by 14-fold (1.15 log units), on the low side; the whole stated range lies below it.
By their numbers in this assay, from the lowest: compound 1; then compound 2; then compound 3.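

In this assay, the group at this position matters a great deal: cyano in place of hydrogen gives a 23-fold higher number from compound 1 to compound 3 (1.37 log units; beyond the scatter), a much larger step than the earlier one for isopropoxy, a 3.1-fold higher number from compound 1 to compound 2 (0.49 log units; beyond the scatter). Swapping one group directly for the other gives a 7.5-fold higher number from compound 2 to compound 3 (0.88 log units; beyond the scatter), so these two substituents are clearly not interchangeable here, even though each counts one hydrogen-bond acceptor. No available evidence explains this difference. On these data alone, whether a methoxy group, an amine or a chlorine atom here would fall closer to compound 1 remains open. So does whether any group at this position can match hydrogen.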